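Series notes: replacing the 2-methylphenyl group of compound 3

This account rests on a few compounds, and the source may have more. Where it says the series, first, only, none or still open, it means among the compounds named here.

Measured in a functional assay on HepG2 cells (Homo sapiens) for antiproliferative activity, read by MTT assay, with a stated time of 48 h; a lower number here means a stronger inhibitor, a higher number a weaker inhibitor:
- Compound 1 `COc1ccc(/C=C/c2cc(OC)cc(OC)c2/C=C/C(=O)c2ccc(Cl)c(Cl)c2)cc1`: 10.8 ug/mL
- Compound 2 `COc1ccc(/C=C/c2cc(OC)cc(OC)c2/C=C/C(=O)c2ccc(F)cc2)cc1`: 12.2 ug/mL
- Compound 3 `COc1ccc(/C=C/c2cc(OC)cc(OC)c2/C=C/C(=O)c2ccccc2C)cc1`: 5.3 ug/mL

Compound 3 has the lowest number of the three. The two steps that reach it are a 2.0-fold lower number from compound 1 to compound 3 (0.31 log units; beyond the scatter) and a 2.3-fold lower number from compound 2 to compound 3 (0.36 log units; beyond the scatter). The remaining pair does not separate, with a 1.1-fold higher number from compound 1 to compound 2 (0.05 log units; within the scatter).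

The next compound is compound 4 `COc1ccc(/C=C/c2cc(OC)cc(OC)c2/C=C/C(=O)c2ccc(OC)cc2)cc1`, and the change is 4-methoxyphenyl in place of 2-methylphenyl on a carbonyl carbon. In words, 4-methoxyphenyl stands in place of 2-methylphenyl on a carbonyl carbon. For the measured compounds named here, no measured compound carries the 4-methoxyphenyl group, so the comparison is indirect. Going by the values given here, the only guidance comes from the two measured compounds that lack the 2-methylphenyl group, and both have higher numbers than compound 3. Compound 4 is therefore expected to fall nearer to them, on the evidence of a 2.3-fold lower number from compound 2 to compound 3 (0.36 log units; beyond the scatter) and a 2.0-fold lower number from compound 1 to compound 3 (0.31 log units; beyond the scatter). Among the compounds with values here, with only three compounds, this expectation remains loose.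

A modest rise is expected in this assay, with the estimated change being a 2.1-fold higher number from compound 3 to compound 4 (0.32 log units; beyond the scatter). The estimate for compound 4 is 11 ug/mL, with an expected range of 5.5 ug/mL to 22 ug/mL.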

Compound 4, half-maximal inhibitory concentration: 4.9 ug/mL
Compound 4: middle estimate off by 2.2-fold (0.35 log units), on the high side; measured number outside the range, below it.
By their numbers in this assay, from the lowest: compounds 4 and 3 (each within the scatter of the next); then compounds 1 and 2 (each within the scatter of the next).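

In this assay the 4-methoxyphenyl group on the carbonyl carbon does not separate from the 2-methylphenyl group (a 1.1-fold lower number from compound 3 to compound 4 (0.03 log units; within the scatter)), so the lower numbers at this position are not unique to the 2-methylphenyl group. The cleanest reading comes from methoxy in place of fluoro on an aromatic carbon (a 2.5-fold lower number from compound 2 to compound 4 (0.40 log units; beyond the scatter)), where only that one substituent differs and the step lies beyond the scatter; the change from the 3,4-dichlorophenyl group also lies beyond it (a 2.2-fold lower number from compound 1 to compound 4 (0.34 log units; beyond the scatter)). Compound 3 and compound 4 therefore form one level and compound 1 and compound 2 another, but no measurement at hand explains what links the members of either level.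

Still open, as far as these compounds go, is whether the 4-methoxyphenyl result extends to a longer ether such as ethoxy, or to an amine or a carboxylic acid on the same aromatic carbon. Also open, from the compounds shown here alone, is how an unsubstituted phenyl group or a cyclohexyl group on the carbonyl carbon would compare with these two levels.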